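The compounds below may be only part of what the source reports. "The series", "measured", "known", "first", "only" and "open" are said of these compounds alone.

Compound 2, of structure `CC(C)=CCn1cnc2c(Nc3cccc(Cl)c3)nc(N[C@H]3CC[C@H](N)CC3)nc21`, is one of two compounds characterised in a functional assay on K562 cells (Homo sapiens) for inhibition, read by fluorescence, with a stated time of 72 h (a higher number here means a weaker inhibitor of growth, a lower number a stronger inhibitor of growth), the other being compound 1, of structure `CCCCCCn1cnc2c(Nc3ccc(Cl)cc3)nc(N[C@H]3CC[C@H](N)CC3)nc21`. In this assay compound 2 gives 3500 nM, while compound 1 gives 2100 nM; the gap between these two numbers is within the usual scatter, so the two compounds cannot be told apart on this read-out. The step considered here leads from compound 2 to compound 3, of structure `CCCCCCn1cnc2c(Nc3cccc(Cl)c3)nc(N[C@H]3CC[C@H](N)CC3)nc21`, which has not yet been measured in this assay. The change is pentyl in place of 2-methylprop-1-en-1-yl on a saturated chain carbon bound to an aromatic nitrogen. Among the measured compounds shown here, no step between measured compounds has been recorded, so the size of this change cannot be read from any pair already in hand. Compound 1 carries a hexyl chain and sits alongside compound 2 within the scatter, which suggests that exchanging the chain on its own does not move this read-out much. On that basis the step from compound 2 to compound 3 is expected to be a 1.4-fold lower number from compound 2 to compound 3 (0.15 log units; within the scatter), that is, no change beyond the scatter. Compound 3 is therefore estimated at 2500 nM, with a range from 1200 nM to 5500 nM.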

Compound 3, concentration for 50% growth inhibition: 2300 nM
Estimate against measurement, compound 3: 1.1-fold (0.04 log units) above; low and high end bracket the measured number.
By their numbers in this assay, from the lowest: compounds 1, 3 and 2 (each within the scatter of the next).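

In this assay, among the compounds shown here, the step at the saturated chain carbon bound to an aromatic nitrogen, pentyl in place of 2-methylprop-1-en-1-yl, is a 1.5-fold lower number from compound 2 to compound 3 (0.18 log units; within the scatter), so the first pair that differs only in this chain shows that removing the double bond outside aromatic rings and exchanging this branched chain for a straight one leaves the read-out within the scatter. The second single change, 3-chlorophenyl in place of 4-chlorophenyl on a nitrogen on an aromatic ring, is a 1.1-fold higher number from compound 1 to compound 3 (0.04 log units; within the scatter), which is also within the scatter, so the differences that compound 1 and compound 2 carried together can now be read one at a time, and neither step separates the compounds. No measurement in hand bears on why these steps are so small.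

As far as these compounds go, whether a chain ending in an amine or a carboxylic acid, or a much longer chain such as dodecyl, would shift the read-out beyond the scatter at this position remains open. From the compounds shown here alone, it is also open whether replacing the chlorine on the phenyl ring with a group such as methoxy or trifluoromethyl would do so.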